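Benzyl for phenyl on the ring amine: expecting compound 4

The source may hold more compounds than are shown below. What is called first, only, known or untested is meant among the compounds shown, and "the series" means these compounds.

Measured in a functional assay on A-375 cells (Homo sapiens) for antiproliferative activity, read by CCK-8 assay, with a stated time of 72 h, tested at 2 uM; a higher number here means a stronger effect of the compound at the concentration tested, a lower number a weaker effect:
compound 1 `Nc1ccccc1NC(=O)c1ccc(CSC(=S)N2CCN(c3ccccc3)CC2)cc1` gives 27.5%
compound 2 `CCN(Cc1ccncc1)C(=S)SCc1ccc(C(=O)Nc2ccccc2N)cc1` gives 67.2%
compound 3 `CC1CCN(C(=S)SCc2ccc(C(=O)Nc3ccccc3N)cc2)CC1` gives 32.7%

Compound 1 stands lowest of the three numbers. Compound 3 is nearest, its number higher by an amount within the scatter, so these two cannot be ordered; compound 2 lies beyond the scatter above compound 1. Among the measured compounds shown here, the one measured step, a number 34.5 percentage points lower from compound 2 to compound 3 (beyond the scatter), concerns the group on the thiocarbonyl carbon, not the amine nitrogen in the ring, so it shows only that the part bound to the thiocarbonyl carbon can move the read-out strongly; it does not bear on the change at hand.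

Compound 4 `Nc1ccccc1NC(=O)c1ccc(CSC(=S)N2CCN(Cc3ccccc3)CC2)cc1` differs from compound 1 by benzyl in place of phenyl on an amine nitrogen in a ring. For the measured compounds named here, no measured pair varies this position, so the direction is open. The expectation for compound 4 in this assay is a step of a number 5.5 percentage points higher from compound 1 to compound 4 (within the scatter), that is, nothing clearly beyond the scatter, with a wide range. Compound 4 is estimated at 33%, between 15% and 55%.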

Compound 4, a percentage reported as inhibition, at one concentration (the size of the read-out at that concentration, not a potency): 10.6%
For compound 4 the middle estimate is 22.4 percentage points above the measured one; the measured number lies below the stated range.
By their numbers in this assay, from the lowest: compound 4; then compounds 1 and 3 (each within the scatter of the next); then compound 2.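

In this assay, among the compounds shown here, benzyl in place of phenyl on the amine nitrogen in the ring gives a number 16.9 percentage points lower from compound 1 to compound 4 (beyond the scatter), the first measured pair at this position. The position therefore responds to the group it carries, and not only the overall part bound to the thiocarbonyl carbon can move the read-out. The two groups match in their aromatic ring, hydrogen-bond donor and acceptor counts and net charge, and no measurement here explains the step.

With one pair, this position has no trend yet, and the direction of the step cannot be extended to other groups on this nitrogen. A 2-phenylethyl or an acetyl group at the same nitrogen would show whether the read-out keeps falling or recovers.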